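Notes on chain length in a dopamine beta-hydroxylase series

The source may report more compounds than this note shows. Statements on the series, on what has been measured and on what is new or still open speak of the compounds shown alone.

Measured in an assay on isolated protein (adrenal medulla) for inhibition of Dopamine beta-hydroxylase (Bos taurus); a lower number here means a stronger inhibitor, a higher number a weaker inhibitor:
- compound 1 `Nc1ncn(Cc2cccc(Cl)c2)c2ncnc1-2` gives 2 ug/mL
- compound 2 `Nc1ncn(Cc2ccccc2Br)c2ncnc1-2` gives 200 ug/mL
- compound 3 `CCCn1cnc(N)c2ncnc1-2` gives 200 ug/mL

Compound 3 stands level with compound 2 at the digits recorded; the two share the highest number of the three, and between them there is no change within the scatter. Compound 1 is the furthest from compound 3, with a number far lower, well beyond the scatter; its side chain is of a wholly different kind, so it tells nothing about chain length on its own.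

Compound 4 `CC(C)CCn1cnc(N)c2ncnc1-2` is still to be measured in this assay this assay. It differs from compound 3 by isopropyl in place of methyl on a saturated chain carbon, two bonds along the chain from an aromatic nitrogen. Within the data shown here, no measured pair shows this change, so the size of the step is unknown; only compound 3 itself anchors the guess. A small step is expected, if any, and the number is expected to move down rather than up, since the larger side chain of compound 1 is the one that gave 2 ug/mL. The estimated value for compound 4 is 100 ug/mL, in a range from 30 ug/mL to 300 ug/mL. The expected step is a 2.0-fold lower number from compound 3 to compound 4 (0.30 log units; within the scatter), close to the edge of the scatter.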

Compound 4, half-maximal inhibitory concentration: 200 ug/mL
Estimate against measurement, compound 4: 2.0-fold (0.30 log units) below; low and high end bracket the measured number.
By their numbers in this assay, from the lowest: compound 1; then compounds 2, 3 and 4 (each within the scatter of the next).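

In this assay, isopropyl in place of methyl on a saturated chain carbon, two bonds along the chain from an aromatic nitrogen, gives no change at the digits printed from compound 3 to compound 4 (within the scatter). Among these compounds, this is the first step that can be read at this position, and it shows that the change from propyl to isopentyl brings no measurable shift in this assay, so extending and branching this saturated chain in this way gives no gain here. Nothing on hand accounts for this flat step.

Going by these compounds, whether a longer unbranched chain such as hexyl, or a chain ending in an amine or a carboxylic acid, would also leave the number unchanged remains open. The low number of compound 1, 2 ug/mL, also stays unconnected to these alkyl chains, as no single change links it to them.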